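The compounds below may be only part of what the source reports. "The series", "measured", "known", "first", "only" and "open" are said of these compounds alone.

Working notes on the series.

Compound 1 `COc1cccc(-c2ccc3ccc(C)nc3c2)c1` gives 860 nM in a functional assay on CHO cells for inhibition of metabotropic glutamate receptor 5 (Rattus norvegicus), read by FLIPR and calcium flux; a lower number here means a stronger inhibitor, a higher number a weaker inhibitor. Compound 2 `COCc1cccc(-c2ccc3ccc(C)nc3c2)c1` gives 5800 nM in this assay; the step of a 6.7-fold lower number from compound 2 to compound 1 (0.83 log units; beyond the scatter) goes with the change (methoxy in place of methoxymethyl on an aromatic carbon). Compound 3 `COCc1cc(C#N)cc(-c2ccc3ccc(C)nc3c2)c1` gives 2 nM in this assay, the lowest number of the three; the step of a 2900-fold lower number from compound 2 to compound 3 (3.46 log units; beyond the scatter) goes with cyano in place of hydrogen on an aromatic carbon.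

Compound 4 `COc1cc(C#N)cc(-c2ccc3ccc(C)nc3c2)c1` has not yet been measured in this assay. It differs from compound 3 by methoxy in place of methoxymethyl on an aromatic carbon, the same kind of change as that from compound 2 to compound 1, but here the place is meta to a cyano group (2 heavy atoms) and meta to a large group, not only meta to a large group. A similar, possibly smaller, step a 2.5-fold lower number from compound 3 to compound 4 (0.40 log units; beyond the scatter) is expected, resting on the step of a 6.7-fold lower number from compound 2 to compound 1 (0.83 log units; beyond the scatter). Compound 4 is estimated at 0.8 nM, between 0.2 nM and 4 nM.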

Compound 4, half-maximal inhibitory concentration: 2.4 nM
Estimate against measurement, compound 4: 3.0-fold (0.48 log units) below; measured number inside the range.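

Methoxy in place of methoxymethyl does not carry over unchanged between the two cores in this assay, since with the cyano group present the change gives a 1.2-fold higher number from compound 3 to compound 4 (0.08 log units; within the scatter) against the earlier step: the same change on two cores in this assay, a 6.7-fold lower number (0.83 log units; beyond the scatter) from compound 2 to compound 1 and a 1.2-fold higher number (0.08 log units; within the scatter) from compound 3 to compound 4, 8.1-fold (0.91 log units) apart, beyond the scatter of two such steps. Cyano in place of hydrogen still gives a 360-fold lower number from compound 1 to compound 4 (2.55 log units; beyond the scatter) on the methoxy core, but its size depends on the core: the same change on two cores in this assay, a 2900-fold lower number (3.46 log units; beyond the scatter) from compound 2 to compound 3 and a 360-fold lower number (2.55 log units; beyond the scatter) from compound 1 to compound 4, 8.1-fold (0.91 log units) apart, beyond the scatter of two such steps. The four compounds show that the two changes do not simply add in this pair of cores, but they do not show why, and one comparison for each change gives no general rule for the series.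

On these data alone, whether a carboxylic acid or an amine in place of the cyano group would give a similar step remains open. So does the effect of a longer chain, such as ethoxymethyl, in place of methoxymethyl.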